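This account rests on a few compounds, and the source may have more. Where it says the series, first, only, none or still open, it means among the compounds named here.

Compound 1, `Cn1c(CO[C@@H]2COc3nc([N+](=O)[O-])cn3C2)cnc1-c1ccc(F)cc1`, gives in an ADME assay on Vero cells (Chlorocebus sabaeus) for cytotoxicity, with a stated time of 72 h (a higher number here means a weaker inhibitor, a lower number a stronger inhibitor), a result of > 128000 nM, which is a limit of the assay and not a number.
Compound 2, `Cn1c(CO[C@@H]2COc3nc([N+](=O)[O-])cn3C2)cnc1-c1ccc(OC(F)(F)F)cc1`, gives in this assay a result of > 128000 nM, again a limit and not a number.
Compound 3, `O=[N+]([O-])c1cn2c(n1)OC[C@@H](OCc1cn(-c3ccc(F)cc3)nn1)C2`, gives in this assay a result of > 128000 nM, also a limit and not a number.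

Compound 1 and compound 2 differ in a single place: trifluoromethoxy in place of fluoro on an aromatic carbon. The step that the two limits leave unreadable from compound 1 to compound 2 cannot be given a size, because both ends of it rest at the limit of > 128000 nM in this assay, at which 3 of the 3 values shown sit. All that the two values show is that neither compound reached a measurable cytotoxic concentration within the range tested.

Compound 3 is built on another core, and the difference between the core of compound 1 and the core of compound 3 is not broken down here. Compound 4, `O=[N+]([O-])c1cn2c(n1)OC[C@@H](OCc1cn(-c3ccc(OC(F)(F)F)cc3)nn1)C2`, has not yet been measured in this assay. It differs from compound 3 by trifluoromethoxy in place of fluoro on an aromatic carbon, the same change that was made from compound 1 to compound 2, at a place described in the same words.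

For compound 4 the expectation is that the step that the limit leaves unreadable from compound 3 to compound 4 will, like the earlier one, be unreadable, because compound 3 already sits at the limit of > 128000 nM in this assay, at which 3 of the 3 values shown sit, and the same change left compound 2 there as well. Compound 4 is therefore estimated to give about 150000 nM in this assay, most likely reported as a limit, with a plausible span from 64000 nM to 400000 nM.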

Compound 4, half-maximal inhibitory concentration: > 128000 nM
Compound 4 was reported as a limit (the forecaster's own chance of this, stated with the estimate: 85%); the middle value lies beyond the limit too.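

Compound 3 and compound 4 both end at a limit of the assay rather than a number, so no size can be read for the step between them: the limit of > 128000 nM in this assay, at which 4 of the 4 values shown sit.

The compounds shown leave open whether trifluoromethoxy in place of fluoro on an aromatic carbon changes the result in this assay at all, on either core, and at what concentration any of these four compounds would register there.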